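Compound 2 to compound 4: chloro replaced by amino

A few compounds are considered here, and "the series" means these few. Any claim that something is new, unique, unknown or untested is made for them only; others in the source may bear on it.

Values in a functional assay on MC-38 cells (Mus musculus) for antiproliferative activity, read by colorimetric assay and MTT assay; on this read-out higher numbers stand for weaker inhibition and lower numbers for stronger inhibition:
- compound 1 `O=S(=O)(Nc1cccc2cc[nH]c12)c1ccc(Cl)cc1` gives 7 ug/mL
- compound 2 `O=S(=O)(Nc1cccc2cc(O)[nH]c12)c1ccc(Cl)cc1` gives 4.5 ug/mL
- compound 3 `O=[N+]([O-])c1ccc(S(=O)(=O)Nc2cccc3c(Cl)c[nH]c23)cc1` gives 0.34 ug/mL

Compound 2 at 4.5 ug/mL sits within the scatter of compound 1 at the upper end of the three numbers. Compound 3 at 0.34 ug/mL lies well lower, beyond the scatter.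

The next compound is compound 4 `Nc1ccc(S(=O)(=O)Nc2cccc3cc(O)[nH]c23)cc1` and the change from compound 2 is amino in place of chloro on an aromatic carbon in which amino stands in place of chloro, para to a large group. The same difference reads 4-chlorophenyl to 4-aminophenyl.

Among the compounds with values here, only one measured step exists, a 1.6-fold lower number from compound 1 to compound 2 (0.19 log units; within the scatter) and it is a hydroxy in place of hydrogen elsewhere in the molecule. It says nothing direct about this swap. Compound 2 differs from compound 3 in more than one place, so the value of compound 3 at 0.34 ug/mL does not isolate the change, though it leaves open that this group matters.

Within the data shown here, with no direct precedent, an estimated step of a 1.1-fold higher number from compound 2 to compound 4 (0.05 log units; within the scatter) is expected in this assay and that means none beyond the scatter. Compound 4 is expected at 5 ug/mL with an estimated range from 1.3 ug/mL to 18 ug/mL as the working figure.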

Compound 4, half-maximal inhibitory concentration: 1.8 ug/mL
Compound 4: the middle estimate sits 2.8-fold (0.44 log units) above what was measured; the range from low to high includes it.
By their numbers in this assay, from the lowest: compound 3; then compound 4; then compounds 2 and 1 (each within the scatter of the next).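

In this assay, within the data shown here, 4-chlorophenyl to 4-aminophenyl gives a 2.5-fold lower number from compound 2 to compound 4 (0.40 log units; beyond the scatter), a modest step and the only one so far that lies beyond the scatter. Among these compounds, the earlier single-place step concerned a hydroxy on the core of compound 1, so this is the first sign that the number responds to what stands on the aromatic carbon para to a large group, and chloro there is not needed to hold the value of compound 2. No measured property accounts for the step, and a single swap cannot separate the loss of chloro from the entry of amino.

From the compounds shown here alone, whether a dimethylamino, an acetamide or a carboxylic acid on this carbon would move the number in the same direction remains open. Also open, going by these compounds, is whether the amino swap gives a similar step on the core of compound 1 or on the chloro-bearing core of compound 3.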